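This account rests on a few compounds, and the source may have more. Where it says the series, first, only, none or still open, it means among the compounds named here.

Three compounds sharing one core were tested in an ADME assay on HepG2 2.2.15 cells (Homo sapiens) for cytotoxicity, read by MTT assay, with a stated time of 8 days; a lower number here means that less compound is tolerated, a higher number that more compound is tolerated. Compound 1 `N#Cc1ccc(Cn2nc(-c3cc(Cl)c(NCC(O)CO)nc3F)c3ccccc3c2=O)cc1` reaches only the limit of the assay, > 100000 nM. Compound 2 `N#Cc1ccc(Cn2nc(-c3cc(Cl)c(NCCC(=O)O)nc3F)c3ccccc3c2=O)cc1` likewise gives only a limit, > 100000 nM. Compound 3 `N#Cc1ccc(Cn2nc(-c3ccc(F)nc3F)c3ccccc3c2=O)cc1` also stops at a limit, > 100000 nM. The step that the two limits leave unreadable from compound 1 to compound 2 thus cannot be read. The untested compound 4 `N#Cc1ccc(Cn2nc(-c3cc(Cl)c(NC[C@@H](O)CO)nc3F)c3ccccc3c2=O)cc1` differs from compound 2 in one place: 1,2-dihydroxyethyl in place of carboxymethyl on a saturated chain carbon bound to a nitrogen on an aromatic ring. Among the measured compounds shown here, the only measured step bearing on this change is the one from compound 1 to compound 2, and it is unreadable because of the limit of > 100000 nM in this assay, at which 3 of the 3 values shown sit. No step beyond the scatter is expected for compound 4 in this assay, so the expected step is a number no higher from compound 2 to compound 4 (the limit leaves the size open). Compound 4 is estimated at 100000 nM, between 50000 nM and 200000 nM, most likely again only a limit.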

Compound 4, half-maximal cytotoxic concentration: > 100000 nM
Compound 4: no number, only a limit; the forecaster's own chance of this, stated with the estimate: 90%; the middle value lies on the limit itself.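

Neither step to compound 4, from compound 1 or from compound 2, can be read, because each compares two limits: the limit of > 100000 nM in this assay, at which 4 of the 4 values shown sit.

Going by these compounds, whether compound 1, compound 2, compound 3 and compound 4 differ at all in this assay stays open.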